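Adding a Second Chloro Group to Compound 3

The source may hold more compounds than are shown below. What is called first, only, known or untested is meant among the compounds shown, and "the series" means these compounds.

Three purine-type compounds have been measured in a functional assay on OVCAR-3 cells (Homo sapiens) for cytotoxicity, read by sulforhodamine B assay, with a stated time of 48 h; a higher number here means a weaker inhibitor of growth, a lower number a stronger inhibitor of growth. Compound 1 `Nc1nc(Cl)c2ncn(Cc3ccc(CCl)cc3)c2n1` gives 5500 nM in this assay. Compound 2 `ClCc1cccc(Cn2cnc3ncnc(Cl)c32)c1` gives 3230 nM. Compound 3 `ClCc1cccc(Cn2cnc3c(Cl)ncnc32)c1` gives 3020 nM, the lowest of the three numbers, though its gaps to compound 2 and to compound 1 both lie within the usual scatter, so no order among the three can be claimed.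

Compound 4 `ClCc1cccc(Cn2cnc3c(Cl)nc(Cl)nc32)c1` has not yet been measured. It differs from compound 3 in one place: chloro in place of hydrogen on an aromatic carbon. Among the compounds with values here, no pair of measured compounds shows this kind of change, so there is no step from which its size could be read. Given that compound 3 gives 3020 nM and that a single added chloro group is a small alteration of the shared core, the expected step from compound 3 to compound 4 in this assay is a 1.2-fold lower number from compound 3 to compound 4 (0.08 log units; within the scatter), a move that may not exceed the scatter. Compound 4 is therefore estimated at 2500 nM, with a range from 1000 nM to 6500 nM.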

Compound 4, concentration for total growth inhibition: 3230 nM
Compound 4: the middle estimate sits 1.3-fold (0.11 log units) below what was measured; measured number inside the range.
By their numbers in this assay, from the lowest: compounds 3, 2, 4 and 1 (each within the scatter of the next).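

In this assay, within the data shown here, chloro in place of hydrogen on the aromatic carbon between two ring nitrogen atoms gives a 1.1-fold higher number from compound 3 to compound 4 (0.03 log units; within the scatter), the first step in this set that can be read for a change in one place. At this position, then, the entry of one chlorine atom produces no change that can be told apart from the scatter of the assay. No measurement bearing on this result is available, so nothing can be said about its cause.

From the compounds shown here alone, whether a methoxy group, a carboxylic acid or a longer chain on the same carbon would move the number beyond the scatter stays open. This single step also cannot show whether chloro in place of hydrogen would give a similar result elsewhere on the shared core.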